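A few compounds are considered here, and "the series" means these few. Any claim that something is new, unique, unknown or untested is made for them only; others in the source may bear on it.

Measured so far in a physicochemical assay for solubility, using the shake flask method, in simulated intestinal fluid, measured as kinetic solubility, with a stated time of 2 h, at 25 degrees C, at pH 6.5; a higher number here means a more soluble compound, a lower number a less soluble compound:
- compound 1 `CCOC(=O)c1nc(C)c2c(c1N)C(=O)N(Cc1ccccc1)C2=O`: < 5000 nM (a limit)
- compound 2 `CCCOC(=O)c1nc(C)c2c(c1N)C(=O)N(Cc1ccccc1)C2=O`: < 5000 nM (a limit)

Compound 2 has no numerical reading, and its value of < 5000 nM is a limit. The same holds across the pair: the limit of < 5000 nM in this assay, at which 2 of the 2 values shown sit. Within the data shown here, the one measured step that bears on the next change is a step that the two limits leave unreadable from compound 1 to compound 2, and it gives no size to carry forward.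

Compound 3 `Cc1nc(C(=O)OC2CC2)c(N)c2c1C(=O)N(Cc1ccccc1)C2=O` has cyclopropyl in place of propyl on an oxygen next to a carbonyl group. Among the measured compounds shown here, with no sized step available, no change beyond the usual scatter is expected in this assay, and no direction can be assigned. The expectation rests only on compound 2 and its limit of < 5000 nM, so another limit is the most likely report. The expected step is a step that the limit leaves unreadable from compound 2 to compound 3. Compound 3 is estimated at 4000 nM, with an expected range of 1500 nM to 8000 nM.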

Compound 3, solubility: 202000 nM
For compound 3 the middle estimate is 51-fold (1.70 log units) below the measured one, and the stated range ends below it.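

In this assay, cyclopropyl in place of propyl on an oxygen next to a carbonyl group gives an at least 40-fold higher number from compound 2 to compound 3 (1.60 log units; beyond the scatter), and cyclopropyl in place of ethyl at the same place gives an at least 40-fold higher number from compound 1 to compound 3 (1.60 log units; beyond the scatter). This place can therefore carry a large step on a change from an open chain to a three-membered ring, with propyl and cyclopropyl both counting 3 carbon atoms. Both steps start from a limit, and the step between compound 1 and compound 2 cannot be read: the limit of < 5000 nM in this assay, at which 2 of the 3 values shown sit.

Open, as far as these compounds go, is how isopropyl or cyclobutyl on this oxygen would read in this assay, and so whether the step follows the ring, its size or the branching alone. Also open, from the compounds shown here alone, is whether the step carries over to a core with a group other than benzyl on the ring nitrogen.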